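The compounds below may be only part of what the source reports. "The series", "measured", "known", "first", "only" and "open" are said of these compounds alone.

Compound 1 `O=C(NCCCNc1cc(-c2cn(-c3ccccc3)nc2-c2cccc(O)c2)ccn1)Nc1ccc(F)cc1`: 2610 nM
Compound 2 `O=C(NCCCNc1cc(-c2cn(-c3ccccc3)nc2-c2cccc(O)c2)ccn1)Nc1cccc(C(F)(F)F)c1`: 2630 nM

In a functional assay on KM12 cells (Homo sapiens) for antiproliferative activity, read by sulforhodamine B assay, with a stated time of 48 h (on this read-out higher numbers stand for weaker inhibition and lower numbers for stronger inhibition), compound 1 gives 2610 nM and compound 2 gives 2630 nM. These two values lie within the scatter of each other, so neither compound can be ranked above the other. Going by the values given here, compound 1 therefore stands level with the only other measured compound.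

The next compound, compound 3 `COc1cccc(-c2nn(-c3ccccc3)cc2-c2ccnc(NCCCNC(=O)Nc3ccc(F)cc3)c2)c1`, differs from compound 1 by methyl in place of hydrogen on an oxygen on an aromatic ring. In words, this is methyl in place of hydrogen on an oxygen on an aromatic ring, which turns hydroxy to methoxy, or 3-hydroxyphenyl to 3-methoxyphenyl.

Among the compounds with values here, the one measured step, a 1.0-fold higher number from compound 1 to compound 2 (0.00 log units; within the scatter), lies within the scatter, but it concerns an amide-type nitrogen and not this oxygen. Within the data shown here, it says little about the new change, and no measured pair shows what this change does. The best starting point is the value of compound 1, 2610 nM, with no direction favoured. The expected step is a 1.1-fold higher number from compound 1 to compound 3 (0.03 log units; within the scatter), which is no clear change, although a real shift cannot be ruled out.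

For compound 3, the estimate is 2800 nM, with an expected range from 900 nM to 9000 nM.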

Compound 3, half-maximal inhibitory concentration: 10500 nM
Compound 3: the middle estimate sits 3.8-fold (0.57 log units) below what was measured; the measured number lies above the stated range.
By their numbers in this assay, from the lowest: compounds 1 and 2 (each within the scatter of the next); then compound 3.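

Turning the 3-hydroxyphenyl group into 3-methoxyphenyl weakens inhibition in this assay, with a 4.0-fold higher number from compound 1 to compound 3 (0.60 log units; beyond the scatter) marking a modest loss that goes beyond the usual scatter. Going by these compounds alone, the earlier comparison changed the group on the amide-type nitrogen and moved the number by no measurable amount, so this is the first place where a single edit clearly shifts the result, and the edit adds only one heavy atom, a methyl on the oxygen on the aromatic ring. The hydrogen on that oxygen therefore cannot be swapped for methyl without a cost in this cell assay, although nothing available here explains why the number rises.

On these data alone, it remains open whether the loss follows from removing that hydrogen or from adding the carbon, and an amino group in place of the hydroxy, or an ethoxy group with its longer chain on the same oxygen, would help to separate those two readings. As far as these compounds go, it is also open whether the same edit costs as much when the 3-(trifluoromethyl)phenyl group of compound 2 replaces the 4-fluorophenyl group.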